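From 3-aminophenyl to 2,4-dichlorophenyl on a shared core

The compounds below may be only part of what the source reports. "The series", "measured", "known", "first", "only" and "open" are said of these compounds alone.

Of the compounds shown here, two with the same core have been measured in a functional assay on A549 cells (Homo sapiens) for antiproliferative activity, read by MTT assay, with a stated time of 72 h; a higher number here means a weaker inhibitor, a lower number a stronger inhibitor. Compound 1 `COc1cc(-n2cnc3ccc(-c4ccc(C(C)=O)cc4)cc32)cc(OC)c1OC`, which carries 4-acetylphenyl, gives 2510 nM. Compound 2 `COc1cc(-n2cnc3ccc(-c4cccc(N)c4)cc32)cc(OC)c1OC`, which carries 3-aminophenyl, gives 640 nM, the lower of the two numbers. The next compound, compound 3 `COc1cc(-n2cnc3ccc(-c4ccc(Cl)cc4Cl)cc32)cc(OC)c1OC`, has not yet been measured. It departs from compound 2 in one place: 2,4-dichlorophenyl in place of 3-aminophenyl on an aromatic carbon. In short, 2,4-dichlorophenyl stands in place of 3-aminophenyl on an aromatic carbon.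

For the measured compounds named here, only one measured step bears on this exchange: a 3.9-fold lower number from compound 1 to compound 2 (0.59 log units; beyond the scatter). It is modest but beyond the scatter, and it shows that replacing the group at this same place can move the number in this assay. Like compound 1, compound 3 lacks the 3-aminophenyl group, so a move towards a higher number of broadly similar size is expected. Going by the values given here, the data hold no measured compound with a chlorine-bearing group, so this expectation remains loose. The expected change is a 2.5-fold higher number from compound 2 to compound 3 (0.40 log units; beyond the scatter). Compound 3 is estimated at 1600 nM, with an expected range from 550 nM to 4500 nM.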

Compound 3, half-maximal inhibitory concentration: > 10000 nM
Compound 3: only a limit was reported (the forecaster's own chance of this, stated with the estimate: 5%); at least 6.2-fold (0.79 log units) between middle value and limit.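

The result for compound 3 in this assay is a limit of the assay and not a number: the limit of > 10000 nM in this assay, at which 1 of the 3 values shown sits. Even so, the change on this aromatic carbon from 3-aminophenyl to 2,4-dichlorophenyl gives an at least 15-fold higher number from compound 2 to compound 3 (1.19 log units; beyond the scatter), a large step, so this position can move the number much further than the first two compounds showed. Compound 3 also separates from the other compound without 3-aminophenyl, with an at least 3.9-fold higher number from compound 1 to compound 3 (0.60 log units; beyond the scatter), so the result at this position is not set by the loss of 3-aminophenyl alone but also depends on the group that takes its place.

As far as these compounds go, how far the true value of compound 3 lies past its limit stays unknown, and so does the full size of both new steps. From the compounds shown here alone, the three groups differ in several ways at once, so it remains open whether a phenyl ring with a single chlorine, an unsubstituted phenyl or a hydroxyl in place of the amine would give a number nearer to that of compound 2 or to that of compound 3.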